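A few compounds are considered here, and "the series" means these few. Any claim that something is new, unique, unknown or untested is made for them only; others in the source may bear on it.

Measured values in a functional assay on HT-29 cells (Homo sapiens) for antiproliferative activity, read by sulforhodamine B assay, with a stated time of 48 h; a lower number here means a stronger inhibitor, a higher number a weaker inhibitor
- Compound 1 (`O=C1NCCN1c1ccc(S(=O)(=O)Nc2ccc(F)cc2)cc1`) gives 370 nM
- Compound 2 (`O=C1NCCN1c1ccc(S(=O)(=O)Nc2ccccc2)cc1`) gives 280 nM
- Compound 3 (`Cc1ccc(NS(=O)(=O)c2ccc(N3CCNC3=O)cc2)c(C)c1`) gives 180 nM

Compound 3 stands beyond the scatter from only one of the other two (a 2.1-fold lower number from compound 1 to compound 3 (0.31 log units; beyond the scatter)), and that step is modest. Its other step stays within the scatter (a 1.6-fold lower number from compound 2 to compound 3 (0.19 log units; within the scatter)). Compound 4 (`COc1ccccc1NS(=O)(=O)c1ccc(N2CCNC2=O)cc1`) has not yet been measured. It carries 2-methoxyphenyl in place of 2,4-dimethylphenyl on a sulfonamide nitrogen. Going by the values given here, no measured compound carries this group, so the evidence is indirect. Changes to the group on that nitrogen have so far moved the number little, as the third measured step also shows (a 1.3-fold lower number from compound 1 to compound 2 (0.12 log units; within the scatter)). No step beyond the scatter is therefore expected in this assay. For compound 4 the expected step is small (a 1.2-fold higher number from compound 3 to compound 4 (0.09 log units; within the scatter)). Compound 4 is estimated at 220 nM (expected range 90 nM to 550 nM).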

Compound 4, half-maximal inhibitory concentration: 550 nM
Beside the measured number, compound 4's estimate is 2.5-fold (0.40 log units) below it; measured number inside the range.
By their numbers in this assay, from the lowest: compounds 3, 2, 1 and 4 (each within the scatter of the next, the first and the last beyond it).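

In this assay, going by these compounds alone, the group on the sulfonamide nitrogen now gives its largest step so far, a 3.1-fold higher number from compound 3 to compound 4 (0.49 log units; beyond the scatter), as 2-methoxyphenyl replaces 2,4-dimethylphenyl. The other two comparisons stay within the scatter, a 2.0-fold higher number from compound 2 to compound 4 (0.29 log units; within the scatter) and a 1.5-fold higher number from compound 1 to compound 4 (0.17 log units; within the scatter), so compound 4 is separated clearly only from compound 3. No measured property here explains this step.

From the compounds shown here alone, whether the methoxy itself matters, or the loss of the two methyl groups, stays open. So does how an amine or a carboxylic acid in place of methoxy would behave.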